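A few compounds are considered here, and "the series" means these few. Any claim that something is new, unique, unknown or untested is made for them only; others in the source may bear on it.

Compound 1 `COc1ccc(Cc2nnc3n2NC(c2ccc([N+](=O)[O-])o2)S3)cc1OC` and compound 2 `COc1ccc(Cc2nnc3n2NC(c2ccc[nH]2)S3)cc1OC` share one core and differ only in the group carried on a saturated ring carbon. In a functional assay on the whole organism (strain Wistar Albino) for inhibition, with Rattus norvegicus as the target, read by paw edema, with a stated time of 1 h, at a dose of 20 mg/kg (a higher number here means more inhibition at the dose given (going by the name of the read-out), a lower number less inhibition), compound 1 gives 14.5%, and compound 2 gives 13.2%. The step between them, a number 1.3 percentage points lower from compound 1 to compound 2 (within the scatter), is within the scatter, so the two numbers stand level and neither compound can be called the weaker; compound 2 simply holds the lower of the two readings. Compound 3 `COc1ccc(Cc2nnc3n2NC(c2cccn2C)S3)cc1OC` differs from compound 2 by methyl in place of hydrogen on an aromatic nitrogen. No measured step exchanges hydrogen for methyl on an aromatic nitrogen; the only step at hand, from 5-nitrofuran-2-yl to 1H-pyrrol-2-yl, moved the read-out little, and so the group on that carbon has shown little influence so far. A small change is therefore expected in this assay, with no clear direction, and the expected step is a number 0.2 percentage points lower from compound 2 to compound 3 (within the scatter). Compound 3 is estimated to give 13%, within a range from 5% to 22%.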

Compound 3, a percentage reported as inhibition, in the whole organism at one dose (the size of the read-out at that dose, not a potency): 13.4%
The estimate for compound 3 lay 0.4 percentage points below the measured number; low and high end bracket the measured number.
By their numbers in this assay, from the lowest: compounds 2, 3 and 1 (each within the scatter of the next).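

Putting methyl in place of hydrogen on the aromatic nitrogen gives a number 0.2 percentage points higher from compound 2 to compound 3 (within the scatter) in this assay, so at this dose the read-out does not depend on that hydrogen being present. Replacing 5-nitrofuran-2-yl with 1-methyl-1H-pyrrol-2-yl gives a number 1.1 percentage points lower from compound 1 to compound 3 (within the scatter), which means that all three groups tried on the saturated ring carbon stand level in this series. No measurement shown here offers an explanation for this flat result.

Still open, on these data alone, is whether a different kind of group on that saturated ring carbon, such as an amine, a carboxylic acid or a longer alkyl chain, would shift the read-out beyond the scatter. As far as these compounds go, it is also open whether something larger than methyl on the aromatic nitrogen, such as benzyl, would do so.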